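Inverting two ring stereocentres of compound 2

The source may report more compounds than this note shows. Statements on the series, on what has been measured and on what is new or still open speak of the compounds shown alone.

In a physicochemical assay for solubility, in phosphate buffer (a lower number here means a less soluble compound, a higher number a more soluble compound), compound 1 (`C[C@H](CO)N1C[C@H](C)[C@H](CN(C)Cc2ccc(Oc3ccccc3)cc2)Oc2c(NC(=O)c3ccncc3)cccc2C1=O`) stands at 98000 nM while compound 2 (`C[C@H]1CN([C@@H](C)CO)C(=O)c2cccc(NC(=O)c3ccncc3)c2O[C@@H]1CN(C)Cc1ccc(Oc2ccccc2)cc1`) stands at 1000 nM and so holds the lower of the two numbers. Compound 3 (`C[C@@H]1CN([C@@H](C)CO)C(=O)c2cccc(NC(=O)c3ccncc3)c2O[C@H]1CN(C)Cc1ccc(Oc2ccccc2)cc1`) changes configuration only (the two compounds have the same atoms and bonds and differ only in configuration as drawn: 2 of 3 stereo elements differ; a stereocentre at a saturated ring carbon is drawn S in compound 2 and R in compound 3; a stereocentre at a saturated ring carbon is drawn S in compound 2 and R in compound 3) with nothing leaving and nothing entering. Among the measured compounds shown here, the one measured step that bears on this is a 98-fold lower number from compound 1 to compound 2 (1.99 log units; beyond the scatter) and it stands with the fact that compounds 1 and 2 differ only in the configuration as drawn as the sole precedent. That step shows a large move without any change in atoms or bonds, but it involved a saturated chain carbon, and the change here involves saturated ring carbons only. Since compound 2 sits at 1000 nM on the low side of just two numbers, a rise is expected. The expected move is an 8.0-fold higher number from compound 2 to compound 3 (0.90 log units; beyond the scatter) and it is estimated to be smaller than the precedent. Compound 3 is estimated at 8000 nM with an expected range from 1000 nM to 80000 nM as the working figure.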

Compound 3, solubility: 1000 nM
The estimate for compound 3 lay 8.0-fold (0.90 log units) above the measured number; measured number inside the range.
By their numbers in this assay, from the lowest: compounds 2 and 3 (each within the scatter of the next); then compound 1.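

In this assay, inverting both saturated ring carbons together leaves the number in place, a result the earlier pair could not show: no change at the digits printed from compound 2 to compound 3 (within the scatter). The other new step is a 98-fold lower number from compound 1 to compound 3 (1.99 log units; beyond the scatter), the same printed size as the earlier step, and it again combines a change at the saturated chain carbon with one at a saturated ring carbon. Among these three compounds, the large steps are therefore the two that include the chain carbon, while the step confined to the ring carbons shows no change at the digits printed.

As far as these compounds go, neither large step changes the chain carbon alone or a single ring carbon alone, so the contribution of each remains open. Also open, from the compounds shown here alone, is whether this pattern would hold with an amine or a carboxylic acid in place of the hydroxyl.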